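Adding a dichlorophenyl carbonyl to compound 3

The source may hold more compounds than are shown below. What is called first, only, known or untested is meant among the compounds shown, and "the series" means these compounds.

Within the data shown here, in a functional assay on SiHa cells (Homo sapiens) for inhibition (on this read-out lower numbers stand for stronger inhibition and higher numbers for weaker inhibition), compound 3 `COc1cc(/C=C/C(=O)c2cccc(N)c2)ccc1O` gives 12.3 ug/mL, the highest of the three numbers so far. Compound 1 `COc1cc(/C=C/C(=O)c2cccc(NC(=O)c3c(Cl)cccc3Cl)c2)ccc1O` gives 3.56 ug/mL, and compound 2 `COc1cc(/C=C/C(=O)c2cccc(NC(=O)c3ccco3)c2)ccc1O` gives 0.76 ug/mL. Compound 4 `COc1cc(/C=C/C(=O)c2cccc(NC(=O)c3ccc(Cl)cc3Cl)c2)ccc1O` has (2,4-dichlorophenyl)carbonyl in place of hydrogen on a nitrogen on an aromatic ring. Among the measured compounds shown here, two measured steps bear on this change, each removing a carbonyl group from that nitrogen: a modest one, a 3.5-fold higher number from compound 1 to compound 3 (0.54 log units; beyond the scatter), and a large one, a 16-fold higher number from compound 2 to compound 3 (1.21 log units; beyond the scatter). Compound 1 carries the more similar group, 2,6-dichlorophenyl, so the modest step is the better guide, and run in reverse it points to a lower number in this assay. The estimated change is a 4.1-fold lower number from compound 3 to compound 4 (0.61 log units; beyond the scatter). For compound 4 the expected value is 3 ug/mL, with an estimated range of 1.2 ug/mL to 8 ug/mL.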

Compound 4, half-maximal inhibitory concentration: 34.4 ug/mL
Compound 4: middle estimate off by 11-fold (1.06 log units), on the low side, outside the stated range (above it).
By their numbers in this assay, from the lowest: compound 2; then compound 1; then compound 3; then compound 4.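

In this assay, placing a carbonyl group on this nitrogen does not always lower the number: a 2.8-fold higher number from compound 3 to compound 4 (0.45 log units; beyond the scatter) here, although compounds 1 and 2 both stand lower than compound 3. The group on the carbonyl carbon strongly shapes the result, with 2,4-dichlorophenyl in place of 2,6-dichlorophenyl giving a 9.7-fold higher number from compound 1 to compound 4 (0.99 log units; beyond the scatter) and in place of furan-2-yl giving a 45-fold higher number from compound 2 to compound 4 (1.66 log units; beyond the scatter) overall. No available evidence explains these differences.

Going by these compounds, whether an unsubstituted phenyl or a short alkyl chain on that carbonyl carbon would stand closer to compound 2 or compound 4 remains open.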